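Swapping bromo for methoxy on the amide-bearing ring

The compounds below may be only part of what the source reports. "The series", "measured", "known", "first", "only" and "open" are said of these compounds alone.

Going by the values given here, compound 2 `COc1cc2oc(-c3cccc(NC(=O)c4ccccc4Br)c3)cc(=O)c2c(OC)c1OC` gives 23100 nM in a functional assay on HepG2 cells (Homo sapiens) for inhibition, read by MTT assay (on this read-out lower numbers stand for stronger inhibition of growth and higher numbers for weaker inhibition of growth), the highest of the two numbers so far; its nearest neighbour, compound 1 `COc1cc2oc(-c3cccc(NC(=O)c4ccccc4)c3)cc(=O)c2c(OC)c1OC`, gives 11700 nM, and the step of a 2.0-fold higher number from compound 1 to compound 2 (0.30 log units; within the scatter) stays within the scatter. Compound 3 `COc1ccccc1C(=O)Nc1cccc(-c2cc(=O)c3c(OC)c(OC)c(OC)cc3o2)c1` differs from compound 2 by methoxy in place of bromo on an aromatic carbon. Among the compounds with values here, no measured step follows methoxy in place of bromo; the only step known, bromo in place of hydrogen at the same place, stayed within the scatter, so nothing beyond the scatter is expected in this assay here either. Compound 3 is therefore estimated at 16000 nM, range 6000 nM to 42000 nM, with an expected step of a 1.4-fold lower number from compound 2 to compound 3 (0.16 log units; within the scatter).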

Compound 3, concentration for 50% growth inhibition: 7530 nM
Compound 3: the middle estimate sits 2.1-fold (0.33 log units) above what was measured; the range from low to high includes it.
By their numbers in this assay, from the lowest: compounds 3, 1 and 2 (each within the scatter of the next, the first and the last beyond it).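

In this assay, going by these compounds alone, the change from 2-bromophenyl to 2-methoxyphenyl gives the first step beyond the scatter at this place on the amide-bearing ring (a 3.1-fold lower number from compound 2 to compound 3 (0.49 log units; beyond the scatter)). Neither group separates from hydrogen, since methoxy also stays within the scatter (a 1.6-fold lower number from compound 1 to compound 3 (0.19 log units; within the scatter)), so only bromo and methoxy differ clearly from each other. No measured data on these compounds explain that gap.

Going by these compounds, whether an amine, a carboxylic acid or a longer chain at this place would shift the number stays open. So does whether bromo and methoxy differ likewise elsewhere on this ring.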